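Fluoro for Hydrogen on the Phenylsulfanyl Group

The compounds below may be only part of what the source reports. "The series", "measured", "known", "first", "only" and "open" are said of these compounds alone.

Compound 1 `Cn1cnc2c(Sc3ccc(F)cc3)ncnc21`: 5%
Compound 2 `Cn1c(-c2ccccc2)nc2c(Sc3ccccc3)ncnc21`: 1%

In an assay on isolated protein for inhibition of Ca2+/calmodulin-dependent protein kinase II (CaM kinase II) (Rattus norvegicus), tested at 30 uM (a lower number here means less inhibition, a higher number more inhibition at the concentration tested (going by the name of the read-out)), compound 1 gives 5% and compound 2 gives 1%. Compound 2 stands lowest of the two numbers, its nearest neighbour being compound 1, whose value lies only a little higher, within the usual scatter. For the measured compounds named here, no step between these two is counted, so only their two values speak. Compound 3 `Cn1c(-c2ccccc2)nc2c(Sc3ccc(F)cc3)ncnc21` differs from compound 2 in one place: fluoro in place of hydrogen on an aromatic carbon. Compound 3 is expected to show a step of a number 2 percentage points higher from compound 2 to compound 3 (within the scatter), not beyond the scatter, because compound 2 gives 1% and both measured values sit near zero. Compound 3 is therefore estimated at 3%, with a range from -4% to 11%.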

Compound 3, a percentage reported as inhibition, at one concentration (the size of the read-out at that concentration, not a potency): 8%
Estimate against measurement, compound 3: 5 percentage points below, within the range that was stated.
By their numbers in this assay, from the lowest: compounds 2, 1 and 3 (each within the scatter of the next).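

In this assay, for the compounds shown here, fluoro in place of hydrogen on the phenylsulfanyl group, para to a large group, gives a number 7 percentage points higher from compound 2 to compound 3 (within the scatter), the first step that can be read at this position. Exchanging a hydrogen of the core for a phenyl group gives a number 3 percentage points higher from compound 1 to compound 3 (within the scatter), so neither change moves the read-out beyond the scatter. Nothing available accounts for either step.

Going by these compounds, whether an amine or a carboxylic acid at the place of the fluoro would give a step beyond the scatter remains open.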